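Methoxy in Place of Methyl on the Shared Core

This account rests on a few compounds, and the source may have more. Where it says the series, first, only, none or still open, it means among the compounds named here.

Compound 1 `CC(=O)/C=C/c1cccc(C(C)(C)C)c1O` and compound 2 `CC(=O)/C=C/c1cc(C)ccc1O` share a core. In a functional assay for inhibition, with Oryctolagus cuniculus as the target (a lower number here means a stronger inhibitor, a higher number a weaker inhibitor), compound 1 gives 2190 nM, while compound 2 gives 8000 nM, the higher of the two numbers and a gap beyond the usual scatter. Compound 3 `COc1ccc(O)c(/C=C/C(C)=O)c1` differs from compound 2 by a single change: methoxy in place of methyl on an aromatic carbon. Among the compounds with values here, no measured pair shows such a change, so only a modest shift in this assay is expected, possibly none beyond the scatter, leaning toward a lower number. The expected step is a 1.6-fold lower number from compound 2 to compound 3 (0.20 log units; within the scatter). Compound 3 is therefore estimated at 5000 nM, within 1500 nM to 15000 nM.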

Compound 3, half-maximal inhibitory concentration: 3980 nM
Beside the measured number, compound 3's estimate is 1.3-fold (0.10 log units) above it; low and high end bracket the measured number.
By their numbers in this assay, from the lowest: compounds 1, 3 and 2 (each within the scatter of the next, the first and the last beyond it).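

In this assay, within the data shown here, methoxy in place of methyl on this aromatic carbon, para to a hydroxy group, gives a 2.0-fold lower number from compound 2 to compound 3 (0.30 log units; within the scatter) in the only pair here that differs in one place. So this position takes the extra oxygen with no shift that stands clear of the scatter, which the earlier two compounds could not show. No measurement at hand offers an explanation for this result. The compounds shown leave open whether an amine, a carboxylic acid or a longer chain such as ethoxy on this carbon would move the number beyond the scatter.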